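The compounds below may be only part of what the source reports. "The series", "measured", "known", "first", "only" and "open" are said of these compounds alone.

Measured compounds:
compound 1 `CC1(C)Oc2ccc(C#N)c(N3CCCC3=O)c2C[C@@H]1O` — 32000 nM
compound 2 `CC1(C)Oc2ccc(C#N)cc2[C@@H](/N=C(\NC#N)Nc2ccccc2)[C@@H]1O` — 1400000 nM
compound 3 `CC(C)(C)c1ccc(C#N)cc1NC(=O)Nc1cccnc1` — 25700000 nM

In a functional assay (aorta) for inhibition, with Rattus norvegicus as the target (on this read-out higher numbers stand for weaker inhibition and lower numbers for stronger inhibition), compound 3 gives the highest of the three numbers, so it is the weakest inhibitor here; its gap to compound 2, the nearest, and to compound 1, the furthest, both lie beyond the usual scatter. Compound 4 `CC(C)(C)c1ccc(C#N)cc1NC(=O)Nc1cnccn1` is the next step: pyrazin-2-yl in place of pyridin-3-yl on an amide-type nitrogen. No comparable change between measured compounds is available, so its effect is open. The expectation is a step from compound 3 to compound 4 of a 1.2-fold higher number from compound 3 to compound 4 (0.07 log units; within the scatter), that is, no change beyond the scatter. Compound 4 is therefore estimated at 30000000 nM, with a range from 8000000 nM to 100000000 nM.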

Compound 4, half-maximal inhibitory concentration: 15300000 nM
Compound 4: middle estimate off by 2.0-fold (0.29 log units), on the high side; the measured number falls inside the stated range.
By their numbers in this assay, from the lowest: compound 1; then compound 2; then compounds 4 and 3 (each within the scatter of the next).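

In this assay, placing pyrazin-2-yl instead of pyridin-3-yl on the amide-type nitrogen gives a 1.7-fold lower number from compound 3 to compound 4 (0.23 log units; within the scatter). At this position, then, the swap to a ring with a second nitrogen, which adds a hydrogen-bond acceptor, does not move the read-out beyond the usual scatter. No supporting data bear on this result. Going by these compounds, whether a non-aromatic cyclohexyl ring or a longer alkyl chain in this place would shift the number remains open. So does the effect of adding an amine or a carboxylic acid to the pyridin-3-yl ring.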